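A few compounds are considered here, and "the series" means these few. Any claim that something is new, unique, unknown or untested is made for them only; others in the source may bear on it.

Compound 3 `Oc1cccc(Nc2nc(-c3cccc(F)c3)nc3ccc(F)cc23)c1` stands beside compound 1 `Fc1ccc(Nc2nc(-c3cccc(F)c3)nc3ccc(F)cc23)cc1` and compound 2 `Fc1cccc(-c2nc(Nc3ccc(Br)cc3)c3cc(F)ccc3n2)c1` in a functional assay on MDA-MB-231 cells (Homo sapiens) for cytotoxicity, read by MTT assay, with a stated time of 48 h; a higher number here means a weaker inhibitor, a lower number a stronger inhibitor. In this assay compound 1 gives > 50000 nM, which is a limit of the assay. In this assay compound 2 gives > 50000 nM, likewise a limit. In this assay compound 3 gives > 50000 nM, again a limit. Compound 4 `Nc1ccccc1Nc1nc(-c2cccc(F)c2)nc2ccc(F)cc12` differs from compound 3 by 2-aminophenyl in place of 3-hydroxyphenyl on a nitrogen on an aromatic ring. The measured steps a step that the two limits leave unreadable from compound 1 to compound 3 and a step that the two limits leave unreadable from compound 2 to compound 3 also exchange the group on a nitrogen on an aromatic ring, and a step that the two limits leave unreadable from compound 1 to compound 2 puts bromo in place of fluoro, yet the limit of > 50000 nM in this assay, at which 3 of the 3 values shown sit, leaves all three unreadable. With every value at a limit, no direction can be read for the coming change. The expected step of a number no higher from compound 3 to compound 4 (the limit leaves the size open) is therefore near zero. Compound 4 is estimated at 50000 nM, between 15000 nM and 150000 nM.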

Compound 4, half-maximal inhibitory concentration: > 50000 nM
Compound 4: no number, only a limit; the forecaster's own chance of this, stated with the estimate: 80%; the middle value lies on the limit itself.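

No step involving compound 4 can be read against compound 1, compound 2 or compound 3 in this assay, because every value sits at one limit: the limit of > 50000 nM in this assay, at which 4 of the 4 values shown sit.

As far as these compounds go, how these four compounds rank against one another in this assay remains open.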